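The compounds below may be only part of what the source reports. "The series", "measured", "known", "first", "only" and "open" are said of these compounds alone.

Compound 1 `CC(C)(C)c1ccc(C(=O)/C=C/c2ccc([N+](=O)[O-])o2)cc1` in an ADME assay on THP-1 cells (Homo sapiens) for cytotoxicity, read by resazurin assay, with a stated time of 72 h (a higher number here means that more compound is tolerated, a lower number that less compound is tolerated), gives > 50000 nM, which is a limit of the assay.
Compound 2 `CC(C)(C)c1ccc(C(=O)/C=C/c2ccco2)cc1` in this assay gives > 50000 nM, also a limit.
Compound 3 `CN(C)c1ccc(/C=C/C(=O)c2ccc(-c3ccccc3)cc2)cc1` in this assay gives > 50000 nM, again a limit.

Compound 1 thus stands only at a limit in this assay, and the other two values sit at the same limit, as the limit of > 50000 nM in this assay, at which 3 of the 3 values shown sit, shows. Within the data shown here, the one measured step that touches compound 1, a step that the two limits leave unreadable from compound 1 to compound 2, has limits at both ends and is not readable. Compound 4 `O=C(/C=C/c1ccc([N+](=O)[O-])o1)c1ccc(N2CCCC2)cc1` differs from compound 1 by pyrrolidin-1-yl in place of tert-butyl on an aromatic carbon. Among the measured compounds shown here, no measured step covers this exchange, and the only evidence at hand, (the limit of > 50000 nM in this assay, at which 3 of the 3 values shown sit), shows nothing but limits, so no shift beyond the scatter in this assay is anticipated. The step of a number no higher from compound 1 to compound 4 (the limit leaves the size open) is accordingly expected to be about nil. Compound 4 is estimated at 50000 nM, within 20000 nM to 120000 nM, most likely reported once more as a limit.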

Compound 4, half-maximal cytotoxic concentration: > 50000 nM
Compound 4: no number, only a limit (the forecaster's own chance of this, stated with the estimate: 80%); the middle value lies on the limit itself.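

Compound 1 and compound 4 both stand at a limit in this assay, so no step can be read between them. The compounds shown leave open where any of them would reach half-maximal cytotoxicity, as all sit at the same limit: the limit of > 50000 nM in this assay, at which 4 of the 4 values shown sit.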